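Swapping Chloro for Methyl on the Urea Aryl Ring

This account rests on a few compounds, and the source may have more. Where it says the series, first, only, none or still open, it means among the compounds named here.

Of the compounds shown here, three built on one shared core have been tested in a functional assay on HT-29 cells (Homo sapiens) for cytotoxicity, read by MTT assay, with a stated time of 72 h; a higher number here means a weaker inhibitor, a lower number a stronger inhibitor. Compound 3 `CCN(CC)CCCNc1nc(-c2ccc(NC(=O)Nc3ccc(Cl)cc3)cc2)nc2c(Cl)c(Cl)sc12` gives 250 nM, the lowest of the three numbers. Compound 2 `CN(C)CCNc1nc(-c2ccc(NC(=O)Nc3ccc(Cl)cc3)cc2)nc2c(Cl)c(Cl)sc12` gives 460 nM; the step of a 1.8-fold lower number from compound 2 to compound 3 (0.26 log units; within the scatter) lies within the scatter, so these two cannot be told apart. Compound 1 `Cc1ccc(NC(=O)Nc2ccc(-c3nc(NCCCN(C)C)c4sc(Cl)c(Cl)c4n3)cc2)cc1` gives 1320 nM, and its gap to compound 3 lies beyond the scatter.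

Compound 4 `CCN(CC)CCCNc1nc(-c2ccc(NC(=O)Nc3ccc(C)cc3)cc2)nc2c(Cl)c(Cl)sc12` has not yet been measured. It differs from compound 3 by methyl in place of chloro on an aromatic carbon. Among the measured compounds shown here, no measured step changes this position on its own. For the measured compounds named here, the single measured step, a 1.8-fold lower number from compound 2 to compound 3 (0.26 log units; within the scatter), concerns the amine chain and was within the scatter. Compound 1 already carries the methyl, but it also has a different chain than compound 3, so the two values alone cannot separate the two changes. Still, because a 1.8-fold lower number from compound 2 to compound 3 (0.26 log units; within the scatter) was within the scatter, much of the gap between compound 1 and compound 3 may belong to the methyl. A higher number is therefore expected for compound 4, with the step of a 3.6-fold higher number from compound 3 to compound 4 (0.56 log units; beyond the scatter) estimated to reach beyond the scatter. Compound 4 is expected at 900 nM, within a range of 350 nM to 2500 nM.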

Compound 4, half-maximal inhibitory concentration: 890 nM
Beside the measured number, compound 4's estimate is 1.0-fold (0.00 log units) above it; the measured number falls inside the stated range.
By their numbers in this assay, from the lowest: compounds 3, 2, 4 and 1 (each within the scatter of the next, the first and the last beyond it).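

The position on the urea aryl ring now has a comparison of its own. Among the compounds shown here, with the diethylamino chain held constant in this assay, methyl in place of chloro gives a step beyond the scatter (a 3.6-fold higher number from compound 3 to compound 4 (0.55 log units; beyond the scatter)), so exchanging this one heavy atom for another is enough to shift the number, an effect that no earlier pair could show separately. With the methyl held constant, diethylamino in place of dimethylamino gives a step within the scatter (a 1.5-fold lower number from compound 1 to compound 4 (0.17 log units; within the scatter)), so these two chain ends cannot be told apart in this pair, and no measurement at hand accounts for the difference between chloro and methyl.

What a fluoro, methoxy or trifluoromethyl group would give at this same place remains open, since only chloro and methyl appear there among the compounds shown. Also open, on these data alone, is whether the step from chloro to methyl would keep its size on a chain ending in a morpholine or a pyrrolidine rather than in diethylamino.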